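Halogen pattern on the aryl ring and antiproliferative potency

The compounds below may be only part of what the source reports. "The series", "measured", "known", "first", "only" and "open" are said of these compounds alone.

compound 1 `C=C(C)[C@H]1CC(=O)C(C)=C2[C@@H](C(=O)OCC)O[C@@H](c3cccc(Br)c3)[C@@H]21`: 30000 nM
compound 2 `C=C(C)[C@H]1CC(=O)C(C)=C2[C@@H](C(=O)OCC)O[C@@H](c3ccccc3Br)[C@@H]21`: 70000 nM

In a functional assay on KB3 cells (Homo sapiens) for antiproliferative activity, read by MTT assay, with a stated time of 96 h (on this read-out higher numbers stand for weaker inhibition and lower numbers for stronger inhibition), compound 1 gives 30000 nM, and compound 2 gives 70000 nM. Within the data shown here, compound 2 stands at the higher of the two numbers, and the single measured step, a 2.3-fold higher number from compound 1 to compound 2 (0.37 log units; beyond the scatter), lies beyond the scatter but is modest in size. Compound 3 `C=C(C)[C@H]1CC(=O)C(C)=C2[C@@H](C(=O)OCC)O[C@@H](c3ccc(Cl)cc3Cl)[C@@H]21` differs from compound 2 by 2,4-dichlorophenyl in place of 2-bromophenyl on a saturated ring carbon. Among the measured compounds shown here, no measured pair swaps bromine for chlorine or adds a second halogen, so this change is only loosely covered; the step of a 2.3-fold higher number from compound 1 to compound 2 (0.37 log units; beyond the scatter) is the sole scale available, and it suggests that rearranging the halogen pattern moves this assay by a modest amount. Compound 3 keeps a halogen in the same position as compound 2, so compound 3 is expected to show a 1.4-fold lower number from compound 2 to compound 3 (0.15 log units; within the scatter), a shift within the scatter. Compound 3 is therefore estimated at 50000 nM, in a range from 15000 nM to 150000 nM.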

Compound 3, half-maximal inhibitory concentration: 3000 nM
Estimate against measurement, compound 3: 17-fold (1.22 log units) above, and the stated range ends above it.
By their numbers in this assay, from the lowest: compound 3; then compound 1; then compound 2.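

In this assay, the aryl group on the saturated ring carbon next to the ring oxygen can move the number much further than the two bromophenyl compounds had indicated: 2,4-dichlorophenyl in place of 2-bromophenyl gives a 23-fold lower number from compound 2 to compound 3 (1.37 log units; beyond the scatter) and, in place of 3-bromophenyl, a 10-fold lower number from compound 1 to compound 3 (1.00 log units; beyond the scatter) as well. Both steps lie beyond the scatter, and compound 3 stands lowest of the three, so at this position the halogen pattern matters more than the earlier pair suggested. Nothing available explains why this change lowers the number so strongly.

The 2,4-dichlorophenyl group changes both the halogen and the number of halogens in one step, so the compounds shown do not separate these two changes. Going by these compounds, whether a 2-chlorophenyl, a 4-chlorophenyl or a 2,4-dibromophenyl group would match compound 3 remains open, as does whether an aminophenyl group would be tolerated at this carbon.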